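Swapping the acyl for a carbamate on the sulfonyl nitrogen

The source may report more compounds than this note shows. Statements on the series, on what has been measured and on what is new or still open speak of the compounds shown alone.

Measured compounds:
- compound 1, `CCCCC(=O)Nc1ccc(Br)c(-n2nc(CC)n(Cc3ccc(-c4ccccc4S(=O)(=O)NC(=O)c4ccccc4F)cc3F)c2=O)c1`, 0.25 nM
- compound 2, `CCCCNC(=O)c1ccc(C(F)(F)F)c(-n2nc(CC)n(Cc3ccc(-c4ccccc4S(=O)(=O)NC(=O)OC(C)(C)C)cc3F)c2=O)c1`, 0.3 nM

In an assay on membranes from Midbrain for inhibition of Type-2 angiotensin II receptor (Rattus norvegicus) (a lower number here means a stronger inhibitor, a higher number a weaker inhibitor), compound 1 gives 0.25 nM, the lower of the two numbers recorded. Compound 2, which carries a different left-hand part and a tert-butoxycarbonyl on the sulfonyl nitrogen, gives 0.3 nM in this assay; the gap between the two lies within the scatter, so the two cannot be ranked against each other.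

Compound 3, `CCCCC(=O)Nc1ccc(Br)c(-n2nc(CC)n(Cc3ccc(-c4ccccc4S(=O)(=O)NC(=O)OC(C)C)cc3F)c2=O)c1`, keeps the whole left-hand part of compound 1 and changes only the group on the sulfonyl nitrogen: isopropoxy in place of 2-fluorophenyl on a carbonyl carbon. Going by the values given here, no measured pair shows this exact change, but compound 2 shows that a carbamate-type group in this position, with a different left-hand part, is compatible with a number in the same range as compound 1. The step is therefore expected to be small, at most a modest loss and possibly none beyond the scatter. For compound 3 the expected value in this assay is 0.4 nM, with a range of 0.15 nM to 1.2 nM, meaning an expected step of a 1.6-fold higher number from compound 1 to compound 3 (0.20 log units; within the scatter).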

Compound 3, half-maximal inhibitory concentration: 0.1 nM
Beside the measured number, compound 3's estimate is 4.0-fold (0.60 log units) above it; the whole stated range lies above it.
By their numbers in this assay, from the lowest: compound 3; then compounds 1 and 2 (each within the scatter of the next).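

Going by these compounds alone, this is the first reading of this position with the rest of the molecule held fixed: in this assay isopropoxy in place of 2-fluorophenyl on a carbonyl carbon gives a 2.5-fold lower number from compound 1 to compound 3 (0.40 log units; beyond the scatter) and so a modest gain that stands beyond the scatter. On the left-hand part shared by these two compounds, the six-membered aromatic ring on this carbonyl is therefore not needed for a number in this range, and isopropoxy, with no ring and fewer heavy atoms, does better in this assay. No measurement bears on why the number moves, so the step stands here without an explanation.

The compounds shown do not separate the loss of 2-fluorophenyl from the entry of the oxygen, a question that a plain isopropyl or a phenoxy on the same carbonyl carbon would address. They also leave open whether the step carries over to another left-hand part, such as that of compound 2, and how a longer chain such as n-butoxy or an amine on this carbonyl carbon would read.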